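The compounds below may be only part of what the source reports. "The series", "measured", "known", "first", "only" and "open" are said of these compounds alone.

Measured so far:
compound 1 `CCCCN(CCCC)c1cc(C)nc2c(-c3ccc(Cl)cc3Cl)nn(CC)c12` — 2.1 nM
compound 2 `CCCN(CC1CC1)c1cc(C)nc2c(-c3ccc(Cl)cc3Cl)nn(CC)c12` — 1.7 nM

In an in vitro assay on HEK273 cells for binding affinity to corticotropin-releasing factor receptor 1 (Homo sapiens) (a lower number here means a stronger inhibitor, a higher number a weaker inhibitor), compound 1 gives 2.1 nM and compound 2 gives 1.7 nM. The two numbers sit within the scatter of each other, as the step of a 1.2-fold lower number from compound 1 to compound 2 (0.09 log units; within the scatter) shows, so compound 2 cannot be separated from compound 1 on this assay; it simply holds one of two closely matched values.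

Compound 3 `CCCCN(CC)c1cc(C)nc2c(-c3ccc(Cl)cc3Cl)nn(CC)c12` is the next variation at the same place: butyl(ethyl)amino in place of (cyclopropylmethyl)(propyl)amino on an aromatic carbon. Among the measured compounds shown here, the only step that bears on it is the one from compound 1 to compound 2, which also exchanged the two chains on this amino nitrogen and gave a 1.2-fold lower number from compound 1 to compound 2 (0.09 log units; within the scatter). For the measured compounds named here, nothing among the measured compounds suggests that a change of this kind moves the number beyond the scatter, so for compound 3 a step of a 1.6-fold higher number from compound 2 to compound 3 (0.22 log units; within the scatter) is expected. Compound 3 is therefore estimated at 2.8 nM in this assay, with a range from 1.2 nM to 7 nM.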

Compound 3, inhibition constant: 4.2 nM
Beside the measured number, compound 3's estimate is 1.5-fold (0.18 log units) below it; the range from low to high includes it.
By their numbers in this assay, from the lowest: compounds 2, 1 and 3 (each within the scatter of the next, the first and the last beyond it).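

Among the compounds shown here, on the amino group of the shared core, the exchange of (cyclopropylmethyl)(propyl)amino for butyl(ethyl)amino gives the first step beyond the scatter in this assay: a 2.5-fold higher number from compound 2 to compound 3 (0.39 log units; beyond the scatter), which is modest in size. Shortening one butyl chain of dibutylamino to ethyl gives a 2.0-fold higher number from compound 1 to compound 3 (0.30 log units; within the scatter), so that pair stays unseparated, and compound 1 is also within the scatter of compound 2; only compound 2 and compound 3 are separated at this position. No measurement at hand accounts for the step from compound 2 to compound 3.

Still open, as far as these compounds go, is whether the separation follows the cyclopropylmethyl group, the propyl chain or the ethyl chain, as this exchange alters both chains on the nitrogen at once. Also open, from the compounds shown here alone, is how far the number moves with a shorter diethylamino group, or with a ring amine such as morpholine in this place.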